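The source may report more compounds than this note shows. Statements on the series, on what has been measured and on what is new or still open speak of the compounds shown alone.

Measured in a physicochemical assay for lipophilicity, using the shake flask method, in phosphate buffer, measured as octanol-water partition, with a stated time of 5 h, at pH 7.4; a lower number here means a more polar compound, a higher number a more lipophilic compound:
- Compound 1 `CN1CCN(c2cc(Nc3ncc(Cl)c(Nc4cccc(CO)c4)n3)cc(S(C)(=O)=O)c2)CC1`: 2.16
- Compound 2 `CC(=O)N1CCN(c2cc(Nc3ncc(C)c(Nc4cccc(CO)c4)n3)cc(S(C)(=O)=O)c2)CC1`: 1.74
- Compound 3 `CN1CCN(c2cc(Nc3ncc(F)c(Nc4cccc(CO)c4)n3)cc(S(C)(=O)=O)c2)CC1`: 1.84

In this assay, compound 2 gives 1.74. That value lies within the scatter of compound 3 and beyond the scatter of compound 1, whose number is the higher of those two.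

The next compound, compound 4 `Cc1cnc(Nc2cc(N3CCN(C)CC3)cc(S(C)(=O)=O)c2)nc1Nc1cccc(CO)c1`, differs from compound 2 by one change: methyl in place of acetyl on an amine nitrogen in a ring. This is methyl in place of acetyl on an amine nitrogen in a ring.

Going by the values given here, no measured step covers this change. Among the compounds with values here, the only measured step, a number 0.32 log units lower from compound 1 to compound 3 (beyond the scatter), is fluoro in place of chloro on an aromatic carbon, so it bears only indirectly. It does show how far apart two compounds with the 4-methylpiperazin-1-yl group can lie. Compound 4 carries that group too, as do compound 1 (2.16) and compound 3 (1.84), so its number is expected to fall near theirs.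

The expected change is modest and upward, a number 0.26 log units higher from compound 2 to compound 4 (within the scatter), and it may not clear the scatter. For compound 4 the estimated value is 2, with an expected range from 1.7 to 2.3.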

Compound 4, distribution coefficient: 1.74
Estimate against measurement, compound 4: 0.26 log units above; measured number inside the range.
By their numbers in this assay, from the lowest: compounds 2, 4 and 3 (each within the scatter of the next); then compound 1.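

In this assay, methyl in place of acetyl on an amine nitrogen in a ring gives a result that can be read directly (no change at the digits printed from compound 2 to compound 4 (within the scatter)), so on this core, exchanging 4-acetylpiperazin-1-yl for 4-methylpiperazin-1-yl leaves no difference that stands out from the scatter. Among the three compounds carrying 4-methylpiperazin-1-yl, methyl in place of fluoro on an aromatic carbon stays within the scatter (a number 0.10 log units lower from compound 3 to compound 4 (within the scatter)), whereas methyl in place of chloro goes beyond it (a number 0.42 log units lower from compound 1 to compound 4 (beyond the scatter)), which sets compound 1 apart from compound 3 and compound 4. Nothing shown here gives a reason for these numbers.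

The compounds shown leave open whether the acetyl to methyl exchange would read the same with chloro or fluoro on the aromatic carbon. They also leave open how a longer chain, such as propyl, or a carboxylic acid would read on that same ring nitrogen.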